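The compounds below may be only part of what the source reports. "The series", "measured", "known", "first", "only" and "open" are said of these compounds alone.

Within the data shown here, compound 1 `CCOC(=O)C1=Cc2ccccc2OC1(OCc1cn(-c2ccc(F)cc2)nn1)C(F)(F)F` is the one compound of the three measured here for which a number rather than a limit is known. In a functional assay on A549 cells (Homo sapiens) for inhibition, read by MTT assay, with a stated time of 24 h (on this read-out higher numbers stand for weaker inhibition and lower numbers for stronger inhibition), compound 1 gives 7300 nM. Compound 2 `O=C(O)C1=Cc2ccccc2OC1(OCc1cc(-c2ccc([N+](=O)[O-])cc2)no1)C(F)(F)F` is a carboxylic acid rather than an ethyl ester; in this assay compound 2 reaches only a limit of the assay, > 150000 nM. Compound 3 `O=C(O)C1=Cc2ccccc2OC1(OCc1cc(-c2ccc(F)cc2)no1)C(F)(F)F` carries fluoro in place of nitro on an aromatic carbon; in this assay compound 3 likewise stops at a limit, > 150000 nM. The step that the two limits leave unreadable from compound 2 to compound 3 therefore cannot be read, because both of its values sit at the limit of > 150000 nM in this assay, at which 2 of the 3 values shown sit.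

Compound 4 `CCOC(=O)C1=Cc2ccccc2OC1(OCc1cn(CC(=O)Nc2ccccc2F)nn1)C(F)(F)F` differs from compound 1 in a single place: ((2-fluorophenyl)carbamoyl)methyl in place of 4-fluorophenyl on an aromatic nitrogen. Among the measured compounds shown here, no measured step bears on this change; the only step that is measured at all, a step that the two limits leave unreadable from compound 2 to compound 3, concerns a different replacement and is unreadable. With no guidance from the data, compound 4 is expected to give 10000 nM, within a range of 3000 nM to 40000 nM. The step of a 1.4-fold higher number from compound 1 to compound 4 (0.14 log units; within the scatter) is thus expected to stay within the usual scatter.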

Compound 4, half-maximal inhibitory concentration: 50100 nM
For compound 4 the middle estimate is 5.0-fold (0.70 log units) below the measured one; the whole stated range lies below it.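

Among these compounds, on the aromatic nitrogen of the five-membered ring, a replacement can now be read for the first time in this assay: ((2-fluorophenyl)carbamoyl)methyl in place of 4-fluorophenyl gives a 6.9-fold higher number from compound 1 to compound 4 (0.84 log units; beyond the scatter). The position is therefore not indifferent to what it carries, and this larger group, with a hydrogen-bond donor and acceptor that 4-fluorophenyl lacks, goes with weaker inhibition, although compound 4 still gives a number rather than a limit of the assay. Nothing among the measurements shown accounts for this step.

The change alters several things at once, so the compounds shown leave open whether the step follows the added chain, the carbonyl or the fluoro on the new ring. A simple benzyl group or an unsubstituted phenyl on that nitrogen would begin to separate these parts.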